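A few compounds are considered here, and "the series" means these few. Any claim that something is new, unique, unknown or untested is made for them only; others in the source may bear on it.

In an ADME assay on BJ cells (Homo sapiens) for antiproliferative activity, with a stated time of 72 h (a higher number here means that more compound is needed for the effect, a lower number that less compound is needed), compound 1 `COc1ccc(-c2cc(=O)c3c(OC)cc(OC)cc3[nH]2)cc1` gives > 62000 nM, which is a limit of the assay and not a number. Compound 2 `COc1ccc(-c2cc(=O)c3c(OC)cc(OC)cc3n2C)cc1` reads 68000 nM and compound 3 `C=CCNC(=O)n1c(-c2ccc(OC)cc2)cc(=O)c2c(OC)cc(OC)cc21` reads 74000 nM, two values within the scatter of each other. Compound 4 `COC(=O)c1cc(=O)c2c(OC)cc(OC)cc2n1C` differs from compound 2 by methoxycarbonyl in place of 4-methoxyphenyl on an aromatic carbon, with methoxycarbonyl in place of 4-methoxyphenyl on an aromatic carbon. The measured steps change only the group on the aromatic nitrogen, so none tests this carbon. Steps from compound 1 stay unreadable because of the limit of > 62000 nM in this assay, at which 1 of the 3 values shown sits. Within the data shown here, the one readable step, a 1.1-fold higher number from compound 2 to compound 3 (0.04 log units; within the scatter), gives no sign of a large shift, so no step beyond the scatter is expected, and the direction stays open. The expected step is a 1.0-fold higher number from compound 2 to compound 4 (0.01 log units; within the scatter). For compound 4 the estimate is 70000 nM, with an expected range from 30000 nM to 150000 nM.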

Compound 4, half-maximal effective concentration: > 37900 nM
Compound 4: no number, only a limit (the forecaster's own chance of this, stated with the estimate: 45%); the middle value does not contradict the limit.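

The result for compound 4 is a limit and not a number, so no step from compound 2 to compound 4 can be read: the limit of > 37900 nM in this assay, at which 1 of the 4 values shown sits.

The compounds shown leave open whether methoxycarbonyl in place of 4-methoxyphenyl on an aromatic carbon changes the number at all.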